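The source may hold more compounds than are shown below. What is called first, only, known or untested is meant among the compounds shown, and "the series" means these compounds.

Measured in a functional assay on MCF7 cells (Homo sapiens) for cytotoxicity, read by MTT assay, with a stated time of 72 h; a lower number here means a stronger inhibitor, a higher number a weaker inhibitor:
- compound 1 `CCC(C)=C1C(=O)N(c2ccc(Cl)cc2)N(c2ccc(Cl)cc2)C1=O`: 41600 nM
- compound 2 `O=C1C(=Cc2ccc(O)cc2)C(=O)N(c2ccc(Cl)cc2)N1c1ccc(Cl)cc1`: 23200 nM
- compound 3 `CN(C)c1ccc(C=C2C(=O)N(c3ccc(Cl)cc3)N(c3ccc(Cl)cc3)C2=O)cc1`: > 128000 nM, a limit and not a number

Compound 3 stands at the limit of > 128000 nM in this assay, at which 1 of the 3 values shown sits. Compound 4 `O=C1C(=Cc2ccc(F)cc2)C(=O)N(c2ccc(Cl)cc2)N1c1ccc(Cl)cc1` carries fluoro in place of dimethylamino on an aromatic carbon, para to a large group: fluoro in place of dimethylamino on an aromatic carbon. Among the compounds with values here, the one measured step bearing on this change is an at least 5.5-fold higher number from compound 2 to compound 3 (0.74 log units; beyond the scatter), where dimethylamino enters rather than leaves. Losing dimethylamino is therefore expected to lower the number in this assay by a similar or larger size, toward compound 2 at 23200 nM. The expected change is an at least 4.5-fold lower number from compound 3 to compound 4 (0.66 log units; beyond the scatter). Compound 4 is estimated at 28000 nM, with an expected range of 9000 nM to 85000 nM.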

Compound 4, half-maximal inhibitory concentration: 31400 nM
The estimate for compound 4 lay 1.1-fold (0.05 log units) below the measured number; the range from low to high includes it.
By their numbers in this assay, from the lowest: compounds 2, 4 and 1 (each within the scatter of the next). At a limit, above all of these: compound 3.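

In this assay, fluoro in place of hydroxy on this aromatic carbon, para to a large group, gives a 1.4-fold higher number from compound 2 to compound 4 (0.13 log units; within the scatter), so these two groups are not separated here. Fluoro in place of dimethylamino gives an at least 4.0-fold lower number from compound 3 to compound 4 (0.61 log units; beyond the scatter), which sets dimethylamino apart from both. Compound 3 is held at a limit and not a number: the limit of > 128000 nM in this assay, at which 1 of the 4 values shown sits.

From the compounds shown here alone, the full size of the dimethylamino step therefore stays open. Also open, going by these compounds, is whether methoxy or a primary amine on this carbon would read with fluoro and hydroxy or with dimethylamino.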